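The compounds below may be only part of what the source reports. "The series", "measured", "known", "first", "only" and "open" are said of these compounds alone.

Three analogues sharing one macrocyclic core have been measured in a functional assay on cells for inhibition, with Murine T-cell line (Mus musculus) as the target; on this read-out lower numbers stand for stronger inhibition and higher numbers for weaker inhibition. Compound 2, `CC[C@@H]1/C=C(\C)C[C@H](C)C[C@H](OC)[C@H]2O[C@@](O)(C(=O)C(=O)N3CCCC[C@H]3C(=O)O[C@H](/C(C)=C/[C@@H]3CC[C@@H](O)[C@H](Oc4ccccc4)C3)[C@H](C)[C@@H](O)CC1=O)[C@H](C)C[C@@H]2OC`, carries a phenoxy group on its cyclohexyl ring; in this assay compound 2 gives 3.2 nM. Compound 1, `CC[C@@H]1/C=C(\C)C[C@H](C)C[C@H](OC)[C@H]2O[C@@](O)(C(=O)C(=O)N3CCCC[C@H]3C(=O)O[C@H](/C(C)=C/[C@@H]3CC[C@@H](O)[C@H](Oc4ccc(C)cc4)C3)[C@H](C)[C@@H](O)CC1=O)[C@H](C)C[C@@H]2OC`, differs from compound 2 by methyl in place of hydrogen on an aromatic carbon; in this assay compound 1 gives 2.6 nM, a step of a 1.2-fold lower number from compound 2 to compound 1 (0.09 log units; within the scatter). Compound 3, `CC[C@@H]1/C=C(\C)C[C@H](C)C[C@H](OC)[C@H]2O[C@@](O)(C(=O)C(=O)N3CCCC[C@H]3C(=O)O[C@H](/C(C)=C/[C@@H]3CC[C@@H](Oc4ccccc4)[C@H](O)C3)[C@H](C)[C@@H](O)CC1=O)[C@H](C)C[C@@H]2OC`, is built from the same atoms as compound 2 but joined differently; the difference between the two cores is not broken down here. In this assay compound 3 gives 5.2 nM, which sits within the usual scatter of the numbers for compound 1 and compound 2.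

Compound 4, `CC[C@@H]1/C=C(\C)C[C@H](C)C[C@H](OC)[C@H]2O[C@@](O)(C(=O)C(=O)N3CCCC[C@H]3C(=O)O[C@H](/C(C)=C/[C@@H]3CC[C@@H](Oc4ccc(C)cc4)[C@H](O)C3)[C@H](C)[C@@H](O)CC1=O)[C@H](C)C[C@@H]2OC`, stands to compound 3 as compound 1 stands to compound 2: the change is methyl in place of hydrogen on an aromatic carbon, the same change made at the same kind of place. Since the change from compound 2 to compound 1 gave a 1.2-fold lower number from compound 2 to compound 1 (0.09 log units; within the scatter), the step from compound 3 to compound 4 is expected to be about as small, a 1.2-fold lower number from compound 3 to compound 4 (0.06 log units; within the scatter). Compound 4 is therefore estimated to give 4.5 nM in this assay, most likely between 2.3 nM and 9 nM.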

Compound 4, half-maximal inhibitory concentration: 6 nM
Estimate against measurement, compound 4: 1.3-fold (0.12 log units) below, within the range that was stated.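

In this assay the change from phenoxy to 4-methylphenoxy gives a 1.2-fold higher number from compound 3 to compound 4 (0.06 log units; within the scatter), and this step cannot be told apart from the one seen on the other core: the same change on two cores in this assay, a 1.2-fold lower number (0.09 log units; within the scatter) from compound 2 to compound 1 and a 1.2-fold higher number (0.06 log units; within the scatter) from compound 3 to compound 4, 1.4-fold (0.15 log units) apart, within the scatter of two such steps. This shows that, for these two cores, the methyl group in this place leaves the number within the scatter on both, so the change carries over without a difference that this read-out can resolve. It does not show a direction for the change, since both steps lie within the scatter, and one pair on each core says nothing about other cores or about larger steps.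

The compounds shown leave open what happens when a group other than methyl stands in the same place on the aromatic ring, such as an amine, a carboxylic acid or a longer chain like butyl. They also leave open whether the two cores would still give matching steps with such groups, or in any other read-out.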